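The source may report more compounds than this note shows. Statements on the series, on what has been measured and on what is new or still open speak of the compounds shown alone.

In a toxicity assay on PC-12 cells (Rattus norvegicus) for cytotoxicity, read by MTT assay (on this read-out higher numbers stand for weaker inhibition and lower numbers for stronger inhibition), compound 1 `CCc1ccc(-n2nc(-c3ccc(C(F)(F)F)cc3O)nc2-c2ccccc2O)cc1` gives 147000 nM, compound 2 `CC(C)c1ccc(-n2nc(-c3ccc(C(F)(F)F)cc3O)nc2-c2ccccc2O)cc1` gives 144000 nM, and compound 3 `Oc1cc(C(F)(F)F)ccc1-c1nc(-c2ccccc2O)n(-c2ccc(I)cc2)n1` gives 73300 nM. Compound 3 therefore sits with the other two, and the repeat scatter of this kind of measurement does not separate it from either.

The next compound, compound 4 `COc1cccc(-n2nc(-c3ccc(C(F)(F)F)cc3O)nc2-c2ccccc2O)c1`, carries 3-methoxyphenyl in place of 4-iodophenyl on an aromatic nitrogen of the shared core (3-methoxyphenyl in place of 4-iodophenyl on an aromatic nitrogen).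

For the measured compounds named here, three measured steps bear on this change, all of them swaps on the same aromatic group. Methyl in place of hydrogen on the ethyl chain gave a 1.0-fold lower number from compound 1 to compound 2 (0.01 log units; within the scatter). Iodo in place of ethyl gave a 2.0-fold lower number from compound 1 to compound 3 (0.30 log units; within the scatter), and iodo in place of isopropyl gave a 2.0-fold lower number from compound 2 to compound 3 (0.29 log units; within the scatter). None of these steps leaves the scatter. Going by the values given here, they are only an indirect guide, however, since no measured compound carries a methoxy group.

On that evidence, no step beyond the scatter is expected in this assay. The expected step is a 1.5-fold higher number from compound 3 to compound 4 (0.18 log units; within the scatter). For compound 4, the estimate is 110000 nM, with an expected range from 55000 nM to 220000 nM.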

Compound 4, half-maximal inhibitory concentration: 56400 nM
Estimate against measurement, compound 4: 2.0-fold (0.29 log units) above; low and high end bracket the measured number.
By their numbers in this assay, from the lowest: compounds 4, 3, 2 and 1 (each within the scatter of the next, the first and the last beyond it).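

In this assay, for the compounds shown here, 3-methoxyphenyl on the aromatic nitrogen brings the first changes at this position that leave the scatter: in place of 4-isopropylphenyl it gives a 2.6-fold lower number from compound 2 to compound 4 (0.41 log units; beyond the scatter) and in place of 4-ethylphenyl it gives a 2.6-fold lower number from compound 1 to compound 4 (0.42 log units; beyond the scatter), both of them modest steps. Against 4-iodophenyl the same group gives a 1.3-fold lower number from compound 3 to compound 4 (0.11 log units; within the scatter), so only the two compounds with a saturated chain on the aromatic ring are separated from compound 4, while compound 3 is not. Nothing shown here explains why these steps have this size.

The entering group differs from the others both in carrying a methoxy group and in having it at another place on the aromatic ring, and no compound shown changes one of these without the other, so their shares in the step stay unresolved. Also open is how the number would respond to an amine or a carboxylic acid on this aromatic ring, since every group shown here is a methoxy group, an iodo group or a short saturated chain.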